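A few compounds are considered here, and "the series" means these few. Any claim that something is new, unique, unknown or untested is made for them only; others in the source may bear on it.

Measured in an assay on microsomes from intestine for inhibition of acyl-CoA:cholesterol acyltransferase (Oryctolagus cuniculus); on this read-out lower numbers stand for stronger inhibition and higher numbers for weaker inhibition:
compound 1 `COc1ccccc1NC(=O)NCC1(c2ccccc2)CCCCC1`: 270 nM
compound 2 `COc1cccc(NC(=O)NCC2(c3ccccc3)CCCCC2)c1`: 2500 nM
compound 3 `Cc1ccc(NC(=O)NCC2(c3ccccc3)CCCCC2)cc1`: 4500 nM

Compound 3 gives the highest number of the three. Against compound 2 the gap is within the scatter, a 1.8-fold higher number from compound 2 to compound 3 (0.26 log units; within the scatter), so the two are not separated; against compound 1 it is beyond it, a 17-fold higher number from compound 1 to compound 3 (1.22 log units; beyond the scatter). The other step, a 9.3-fold higher number from compound 1 to compound 2 (0.97 log units; beyond the scatter), is likewise beyond the scatter.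

Compound 4 `O=C(NCC1(c2ccccc2)CCCCC1)Nc1ccc(Cl)cc1` differs from compound 3 by chloro in place of methyl on an aromatic carbon. Within the data shown here, no measured step exchanges a group at this place of the ring; the measured steps move a methoxy group between positions or replace it by methyl elsewhere. Among the measured compounds shown here, the only step that ends at compound 3, a 1.8-fold higher number from compound 2 to compound 3 (0.26 log units; within the scatter), is within the scatter. Nothing here supports a step beyond the scatter in this assay, so for compound 4 a change of a 1.1-fold lower number from compound 3 to compound 4 (0.05 log units; within the scatter) is expected, with the number staying near that of compound 3. The estimate for compound 4 in this assay is 4000 nM, with a range from 1300 nM to 12000 nM.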

Compound 4, half-maximal inhibitory concentration: 2200 nM
Compound 4: the middle estimate sits 1.8-fold (0.26 log units) above what was measured; the measured number falls inside the stated range.
By their numbers in this assay, from the lowest: compound 1; then compounds 4, 2 and 3 (each within the scatter of the next, the first and the last beyond it).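

In this assay, among these compounds, chloro in place of methyl, on an aromatic carbon para to a large group, is the first measured exchange of one group for another at this place, and it gives a modest step just beyond the scatter (a 2.0-fold lower number from compound 3 to compound 4 (0.31 log units; beyond the scatter)). Compound 4 is not separated from the 3-methoxyphenyl compound (a 1.1-fold lower number from compound 2 to compound 4 (0.06 log units; within the scatter)), and the 2-methoxyphenyl compound remains well apart from it (an 8.1-fold higher number from compound 1 to compound 4 (0.91 log units; beyond the scatter)), so the chloro exchange does not close that gap. Nothing measured on these compounds explains the chloro step.

In the step to compound 1, the group and its place on the ring change together, which leaves open how chloro or methyl would read at the place of the 2-methoxy group. On these data alone, how an amine, a carboxylic acid or a nitrile would read in place of chloro also remains open.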